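Fluoro in Place of Hydrogen: From Compound 1 to Compound 3

A few compounds are considered here, and "the series" means these few. Any claim that something is new, unique, unknown or untested is made for them only; others in the source may bear on it.

Compound 1, `O[C@@H]1Cc2ccccc2N[C@H](c2ccccc2Cl)C1`, was tested in an ADME assay on Vero cells (Chlorocebus sabaeus) for cytotoxicity, read by MTT assay, with a stated time of 72 h; on this read-out lower numbers stand for higher toxicity in this test and higher numbers for lower toxicity in this test. For compound 1 the result is a limit of the assay rather than a number, > 300000 nM. This is the limit of > 300000 nM in this assay, at which 1 of the 2 values shown sits. Compound 2, `Cc1ccc2c(c1)C[C@@H](O)C[C@@H](c1ccccc1Cl)N2`, carries a methyl in place of a hydrogen on an aromatic carbon of the shared core, and in this assay compound 2 gives 82400 nM. That is an at least 3.6-fold lower number from compound 1 to compound 2 (0.56 log units; beyond the scatter), so the methyl moves the number downward, toward higher toxicity.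

Compound 3, `O[C@@H]1Cc2ccccc2N[C@H](c2c(F)cccc2Cl)C1`, differs from compound 1 by fluoro in place of hydrogen on an aromatic carbon. Going by the values given here, no measured step involves a fluoro, and the only measured step concerns a methyl on a different aromatic carbon, so it bears only loosely on this change. Fluoro brings in 1 heavy atom and no donors or acceptors, and with compound 1 sitting at a limit the most likely outcome is a number close to that limit, or a limit again. The expected step is an at least 1.3-fold lower number from compound 1 to compound 3 (0.13 log units; that floor lies within the scatter), within or only just beyond the scatter. The estimate for compound 3 is therefore 220000 nM, with a range from 90000 nM to 350000 nM.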

Compound 3, half-maximal cytotoxic concentration: > 300000 nM
Compound 3 ended at the assay's limit; the forecaster's own chance of this, stated with the estimate: 45%; middle value at least 1.3-fold (0.13 log units) from the limit.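

In this assay compound 3 gives > 300000 nM as a limit of the assay and not a number. Going by these compounds alone, compound 1 sits at the same limit, so no step between compound 1 and compound 3 can be read: the limit of > 300000 nM in this assay, at which 2 of the 3 values shown sit. The compounds shown leave open whether fluoro in place of hydrogen changes this number at all, and in which direction.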